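The source may report more compounds than this note shows. Statements on the series, on what has been measured and on what is new or still open speak of the compounds shown alone.

Measured so far: compound 2 `O=C(Nc1ccc(Oc2cc(C(F)(F)F)cc(C(F)(F)F)c2)cc1)c1cc(Cl)ccc1F` gives 1110 nM in an assay on HEK293 cells for inhibition of Toll-like receptor 8 (Homo sapiens), with a stated time of 16 h (on this read-out higher numbers stand for weaker inhibition and lower numbers for stronger inhibition), and compound 1 `N#Cc1c(Cl)cccc1Oc1ccc(-c2nnco2)cc1` gives 1400 nM.

Compound 2 thus has the lower of the two numbers, but its gap to compound 1 lies within the scatter of repeated measurements, so the two cannot be told apart on these values. Compound 3 `O=C(Nc1ccc(Oc2cc(C(F)(F)F)cc(C(F)(F)F)c2)cc1)c1ccc(I)cc1F` is not yet measured. It differs from compound 2 by 2-fluoro-4-iodophenyl in place of 5-chloro-2-fluorophenyl on a carbonyl carbon. Within the data shown here, no step between measured compounds is available to guide the size of this change, since compound 1 and compound 2 differ in more than one place. With both compounds sitting at similar values and the change confined to one aromatic ring, the step from compound 2 to compound 3 is expected to stay within the scatter, with no clear direction: a 1.1-fold lower number from compound 2 to compound 3 (0.05 log units; within the scatter). Compound 3 is therefore estimated at 1000 nM, with a range from 350 nM to 3000 nM.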

Compound 3, half-maximal inhibitory concentration: > 50000 nM
Compound 3 gave a limit, no number; the forecaster's own chance of this, stated with the estimate: 5%; middle value at least 50-fold (1.69 log units) from the limit.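

Among these compounds, exchanging 5-chloro-2-fluorophenyl for 2-fluoro-4-iodophenyl on a carbonyl carbon gives an at least 45-fold higher number from compound 2 to compound 3 (1.65 log units; beyond the scatter), the first step that can be read, whereas the earlier pair differed in more than one place. The two groups have the same heavy-atom count and the same kind of ring, and neither carries hydrogen-bond donors or acceptors, so a swap that leaves all of these unchanged can still carry a large step at this position. In this assay compound 3 gives a limit of the assay, not a number: the limit of > 50000 nM in this assay, at which 1 of the 3 values shown sits.

The compounds shown leave open whether the step follows from the iodine, from the loss of the chlorine or from where the halogen sits on the ring. Nor do they show how a 2-fluoro-5-iodophenyl or a 4-chloro-2-fluorophenyl group would read at this position.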